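The source may hold more compounds than are shown below. What is called first, only, known or untested is meant among the compounds shown, and "the series" means these compounds.

Compound 3 `Cn1c(C2CC2)nc2ccc(-n3ccc(OCc4cccc(Cl)c4)cc3=O)cc21` gives, in an assay on CHO cells for displacement of a labelled ligand from melanin-concentrating hormone receptor 1 (Rattus norvegicus), read by scintillation counting, with a stated time of 1 h (on this read-out higher numbers stand for weaker inhibition and lower numbers for stronger inhibition), a value of 72 nM. Among the numbers shown, that of compound 3 is the highest of two, the nearest being compound 1 `CCc1nc2ccc(-n3ccc(OCc4ccc(F)cc4)cc3=O)cc2n1C`, which in this assay gives 38 nM, a gap within the scatter. Compound 2 `Cn1c(CC(C)(C)C)nc2ccc(-n3ccc(OCc4ccc(F)cc4)cc3=O)cc21` gives only a limit of the assay, > 1000 nM. Among the measured compounds shown here, the single measured step, an at least 26-fold higher number from compound 1 to compound 2 (1.42 log units; beyond the scatter), concerns the chain on the shared core and not the ether. Compound 4 `Cn1c(C2CC2)nc2ccc(-n3ccc(OCc4cc(C(F)(F)F)cs4)cc3=O)cc21` differs from compound 3 by 4-(trifluoromethyl)thiophen-2-yl in place of 3-chlorophenyl on a saturated chain carbon bound to an oxygen on an aromatic ring. For the measured compounds named here, no measured step touches that part of the molecule, so the change is without a guide. For compound 4 the expected step is a 1.4-fold higher number from compound 3 to compound 4 (0.14 log units; within the scatter), not beyond the scatter. Compound 4 is therefore estimated at 100 nM, between 35 nM and 300 nM.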

Compound 4, half-maximal inhibitory concentration: 17 nM
Compound 4: middle estimate off by 5.9-fold (0.77 log units), on the high side; measured number below the stated range.
By their numbers in this assay, from the lowest: compound 4; then compounds 1 and 3 (each within the scatter of the next). At a limit, above all of these: compound 2.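

In this assay, among the compounds shown here, 4-(trifluoromethyl)thiophen-2-yl in place of 3-chlorophenyl gives a 4.2-fold lower number from compound 3 to compound 4 (0.63 log units; beyond the scatter), the first measured step at this place on the shared core. This position therefore accepts a five-membered aromatic ring with 1 hetero atom in place of a six-membered ring of carbon only, with stronger inhibition. Nothing at hand accounts for this step. The compounds shown leave open whether the ring or the trifluoromethyl group carries the step, as the two enter together, and what an amine or a carboxylic acid would give here.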